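The source may hold more compounds than are shown below. What is called first, only, known or untested is meant among the compounds shown, and "the series" means these compounds.

Measured so far in a functional assay on HEp-2 cells (Homo sapiens) for antiproliferative activity, read by MTT assay, with a stated time of 72 h; on this read-out lower numbers stand for stronger inhibition and higher numbers for weaker inhibition:
- compound 1 `O=c1c(SC(=S)N2CCCC2)coc2ccc(Cl)cc12`: 26000 nM
- compound 2 `O=c1c(CSC(=S)N2CCN(C(c3ccc(F)cc3)c3ccc(F)cc3)CC2)coc2ccccc12`: 9600 nM

In this assay compound 1 gives 26000 nM, the highest of the two numbers; compound 2 gives 9600 nM, a lower number beyond the scatter.

Compound 3 `O=c1c(SC(=S)N2CCCC2)coc2ccccc12` is not yet measured. It differs from compound 1 by hydrogen in place of chloro on an aromatic carbon. Within the data shown here, no step between measured compounds covers this change. A small step toward a higher number, within or just beyond the scatter, is expected, a 1.5-fold higher number from compound 1 to compound 3 (0.19 log units; within the scatter). Compound 3 is accordingly estimated at 40000 nM, with a range from 13000 nM to 120000 nM.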

Compound 3, half-maximal inhibitory concentration: 7400 nM
Beside the measured number, compound 3's estimate is 5.4-fold (0.73 log units) above it; measured number outside the range, below it.
By their numbers in this assay, from the lowest: compounds 3 and 2 (each within the scatter of the next); then compound 1.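

In this assay, hydrogen in place of chloro on this aromatic carbon gives a 3.5-fold lower number from compound 1 to compound 3 (0.55 log units; beyond the scatter). The chloro is therefore not required for inhibition in this pair, and the position responds to this change, with the stronger inhibition lying with hydrogen. No available evidence bears on the direction of this step.

From the compounds shown here alone, how a fluoro, a methoxy or an amine on this aromatic carbon would compare with chloro and hydrogen remains open. Also open, going by these compounds, is whether the same step would hold with the rest of the molecule changed.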